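This account rests on a few compounds, and the source may have more. Where it says the series, first, only, none or still open, it means among the compounds named here.

Working notes on the series. In a functional assay on Hep 3B2 cells (Homo sapiens) for inhibition, read by sulforhodamine B assay, with a stated time of 72 h (on this read-out lower numbers stand for stronger inhibition and higher numbers for weaker inhibition), compound 1 `CC(c1ccc(-c2ccccc2)c(F)c1)c1nnc2n1N=C(c1ccc(Cl)cc1Cl)CS2` gives 4200 nM, the higher of the two numbers recorded. Compound 3 `COc1ccc2cc(C(C)c3n[nH]c(=S)n3N)ccc2c1` gives 1900 nM in this assay, a lower number than compound 1 by a margin beyond the scatter. Compound 2 `CC(c1ccc(-c2ccccc2)c(F)c1)c1n[nH]c(=S)n1N` is reported as "not active" (no number reported) in this assay, without a number. Compound 4 `CC(c1ccc(-c2ccccc2)c(F)c1)c1nnc2n1N=C(c1ccc(Br)cc1)CS2` is not yet measured. It differs from compound 1 by 4-bromophenyl in place of 2,4-dichlorophenyl on a carbon with a double bond to nitrogen. For the measured compounds named here, no step across this kind of change has been measured in this assay. The expected step of a 1.2-fold higher number from compound 1 to compound 4 (0.08 log units; within the scatter) is small, with no direction claimed beyond the scatter. Compound 4 is estimated at 5000 nM, in a range of 1500 nM to 16000 nM.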

Compound 4, half-maximal inhibitory concentration: 1500 nM
Estimate against measurement, compound 4: 3.3-fold (0.52 log units) above; measured number inside the range.
By their numbers in this assay, from the lowest: compounds 4 and 3 (each within the scatter of the next); then compound 1.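

In this assay, for the compounds shown here, the step of a 2.8-fold lower number from compound 1 to compound 4 (0.45 log units; beyond the scatter) is the first one read at this position: the aryl group on the carbon with a double bond to nitrogen can shift the number beyond the scatter while the rest of compound 1 stays fixed. No measurement on hand explains this step.

The change alters the halogen and the number of halogens together, and the compounds shown do not separate the two. Also open, as far as these compounds go, is how 4-chlorophenyl, or a phenyl carrying an amine or a carboxylic acid, would read at this position.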